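The source may hold more compounds than are shown below. What is called first, only, known or untested is meant among the compounds shown, and "the series" means these compounds.

For the measured compounds named here, compound 3 `O=C(CCCCCCc1ccccc1)c1ncc(C(=O)C(F)(F)F)o1` is one of three compounds measured in an assay on HEK-293T cells for inhibition of diacylglycerol lipase-alpha (Homo sapiens), read by colorimetric assay; on this read-out higher numbers stand for weaker inhibition and lower numbers for stronger inhibition. Compound 1 `O=C(CCCCCc1ccccc1)c1nc2ccc([N+](=O)[O-])cc2o1` gives 87.1 nM there. Compound 2 `O=C(CCCCCCc1ccccc1)c1nnc(-c2cccs2)s1` gives > 10000 nM, which is a limit of the assay rather than a number. Compound 3 gives 1820 nM, the higher of the two numbers shown; its nearest neighbour is compound 1, whose number lies well below it, beyond the scatter. The step to compound 4 `CN(C)C(=O)c1cnc(C(=O)CCCCCCc2ccccc2)o1` puts (dimethylamino in place of trifluoromethyl on a carbonyl carbon). Going by the values given here, no measured pair shows this change, so its effect is not known from the data. A shift toward weaker inhibition is expected for compound 4, of a size that may pass beyond the scatter. Compound 4 is estimated at 6000 nM, with a range from 1500 nM to 20000 nM. The expected step is a 3.3-fold higher number from compound 3 to compound 4 (0.52 log units; beyond the scatter).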

Compound 4, half-maximal inhibitory concentration: > 10000 nM
Compound 4 gave a limit, no number; the forecaster's own chance of this, stated with the estimate: 35%; middle value at least 1.6-fold (0.22 log units) from the limit.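

The change from trifluoromethyl to dimethylamino on a carbonyl carbon is the only one-place comparison shown, and it moves toward weaker inhibition in this assay: an at least 5.4-fold higher number from compound 3 to compound 4 (0.73 log units; beyond the scatter). For the compounds shown here, this shows that inhibition at this position depends on the group carried by the carbonyl carbon, which the earlier compounds, differing in more than one place, could not show. The value of compound 4 is a limit and not a number, so the step gives only a lower bound: the limit of > 10000 nM in this assay, at which 2 of the 4 values shown sit.

On these data alone, how far inhibition falls with dimethylamino remains open. Also open, as far as these compounds go, is how a carboxylic acid, a nitrile or a primary amide on this aromatic carbon would read in this assay.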